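Phenyl for pyridin-3-yl: expected effect on inhibition

A few compounds are considered here, and "the series" means these few. Any claim that something is new, unique, unknown or untested is made for them only; others in the source may bear on it.

Measured so far:
compound 1, `CC(C)(C)/N=c1\c(O)c(O)\c1=N/Cc1cccnc1`: 2600 nM
compound 2, `CCCC/N=c1\c(O)c(O)\c1=N/Cc1ccc(C#N)cc1`: > 30000 nM

In a functional assay for inhibition, with Rattus norvegicus as the target (on this read-out lower numbers stand for stronger inhibition and higher numbers for weaker inhibition), compound 1 gives 2600 nM. In this assay (this assay) compound 2 returns only a limit, > 30000 nM, and not a number. Among the measured compounds shown here, compound 1 therefore holds the only proper number so far, the other value sitting at the limit of > 30000 nM in this assay, at which 1 of the 2 values shown sits. For the measured compounds named here, compound 2 differs from compound 1 in more than one place, so no single step between measured compounds can be read from the pair.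

Compound 3, `CC(C)(C)/N=c1\c(O)c(O)\c1=N/Cc1ccccc1`, is the next candidate; its difference from compound 1 is phenyl in place of pyridin-3-yl on a saturated chain carbon bound to a double-bonded nitrogen. Going by the values given here, no measured step covers this change. The expected step is a 1.2-fold higher number from compound 1 to compound 3 (0.06 log units; within the scatter), no larger than the usual scatter and without a clear direction. For compound 3 in this assay the estimate is 3000 nM, with a range from 1000 nM to 10000 nM.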

Compound 3, half-maximal inhibitory concentration: 3400 nM
Compound 3: middle estimate off by 1.1-fold (0.05 log units), on the low side, and the stated range covers the measured number.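

In this assay, among the compounds shown here, the change on a saturated chain carbon bound to a double-bonded nitrogen gives a 1.3-fold higher number from compound 1 to compound 3 (0.12 log units; within the scatter) and is the first single-place comparison. Phenyl in place of pyridin-3-yl removes the ring nitrogen and the hydrogen-bond acceptor counted with it, yet compound 1 and compound 3 cannot be told apart in this read-out, so this pair shows no dependence of inhibition on that ring nitrogen. Nothing available here bears on the cause of this result.

For the compounds shown here, compound 2 differs from both compound 1 and compound 3 in more than one place, so no step involving it can be read. As far as these compounds go, whether a non-aromatic cyclohexyl ring, or a phenyl ring carrying an amine or a carboxylic acid, would be tolerated equally at this place remains open.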